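Chloro between ring nitrogens: a repeated step across two cores

The compounds below may be only part of what the source reports. "The series", "measured", "known", "first", "only" and "open" are said of these compounds alone.

Three chlorobenzyl purines were tested in a functional assay on K562 cells (Homo sapiens) for cytotoxicity, read by sulforhodamine B assay, with a stated time of 48 h; a higher number here means a weaker inhibitor of growth, a lower number a stronger inhibitor of growth. Compound 1 `ClCc1ccccc1Cn1cnc2c(Cl)nc(Cl)nc21` gives 150 nM, compound 2 `ClCc1ccccc1Cn1cnc2c(Cl)ncnc21` gives 1200 nM, and compound 3 `ClCc1cccc(Cn2cnc3c(Cl)ncnc32)c1` gives 3540 nM. From compound 2 to compound 1 the change is chloro in place of hydrogen on an aromatic carbon, and it made a step of an 8.0-fold lower number from compound 2 to compound 1 (0.90 log units; beyond the scatter). Compound 3 has the same atoms as compound 2, joined differently; the difference between the two cores is not broken down here. Compound 4 `ClCc1cccc(Cn2cnc3c(Cl)nc(Cl)nc32)c1` is not yet measured; it differs from compound 3 by chloro in place of hydrogen on an aromatic carbon, the same change as from compound 2 to compound 1. Because that step was an 8.0-fold lower number from compound 2 to compound 1 (0.90 log units; beyond the scatter), a step of a 7.1-fold lower number from compound 3 to compound 4 (0.85 log units; beyond the scatter) is expected for compound 4, slightly tempered since it rests on one pair. Compound 4 is therefore estimated at 500 nM, likely between 200 nM and 1500 nM.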

Compound 4, concentration for 50% growth inhibition: 1580 nM
Compound 4: the middle estimate sits 3.2-fold (0.50 log units) below what was measured; the whole stated range lies below it.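

On the second core, chloro between two ring nitrogen atoms gave a 2.2-fold lower number from compound 3 to compound 4 (0.35 log units; beyond the scatter) in this assay, so the direction of the step carried over, but its size did not: the same change on two cores in this assay, an 8.0-fold lower number (0.90 log units; beyond the scatter) from compound 2 to compound 1 and a 2.2-fold lower number (0.35 log units; beyond the scatter) from compound 3 to compound 4, 3.6-fold (0.55 log units) apart, beyond the scatter of two such steps.

These two pairs show that the change lowered the number on both cores, yet they do not show that the size of the step on one core can be used for the other. Nor do they show what sets the two steps apart.

The compounds shown leave open whether an amine or a methoxy group in that same place would lower the number as chloro does. They also leave open whether the step would persist if the chloromethyl group gave way to a hydroxymethyl group or a longer chain.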